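This account rests on a few compounds, and the source may have more. Where it says the series, first, only, none or still open, it means among the compounds named here.

Working notes on the series. The shared core carries a thioether-linked heteroaryl group, and three members have been run in a functional assay on MDA-MB-231 cells (Homo sapiens) for antiproliferative activity, read by MTT assay, with a stated time of 48 h; a lower number here means a stronger inhibitor, a higher number a weaker inhibitor. Compound 1 `O=C(Nc1cc(Sc2ncnc3nc[nH]c23)c(O)c2ccccc12)c1ccc(Cl)cc1` gives 23000 nM in this assay. Compound 2 `COc1ccc(/C=C/C(=O)Nc2cc(Sc3ncn[nH]3)c(O)c3ccccc23)cc1OC` differs from compound 1 in the amide part as well as in the heteroaryl group; in this assay compound 2 gives 52500 nM. Compound 3 `O=C(Nc1cc(Sc2nncs2)c(O)c2ccccc12)c1ccc(Cl)cc1` gives only a limit in this assay, > 100000 nM. Among the measured compounds shown here, the one step between compounds that differ in a single place, an at least 4.3-fold higher number from compound 1 to compound 3 (0.63 log units; beyond the scatter), places compound 3 at the weak end of what has been measured so far; how far beyond that it lies is not known, since compound 3 sits at the limit of > 100000 nM in this assay, at which 1 of the 3 values shown sits.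

Compound 4 `Cn1nnnc1Sc1cc(NC(=O)c2ccc(Cl)cc2)c2ccccc2c1O` follows from compound 3 by one change: 1-methyl-1H-tetrazol-5-yl in place of 1,3,4-thiadiazol-2-yl on a sulfur. For the measured compounds named here, no measured step exchanges one five-membered heteroaryl ring for another of similar size, so the step from compound 1 to compound 3, which replaced a fused bicyclic group by a single ring, is the only guide and bears on it loosely. With compound 3 already at a limit, compound 4 is expected to remain in the weak region, the step of a number no higher from compound 3 to compound 4 (the limit leaves the size open) being estimated as within the scatter. Compound 4 is therefore estimated at 100000 nM, with a range from 30000 nM to 300000 nM.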

Compound 4, half-maximal inhibitory concentration: > 100000 nM
Compound 4: only a limit was reported; the forecaster's own chance of this, stated with the estimate: 60%; the middle value sits exactly at the limit.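

In this assay compound 4 gives only a limit of the assay, > 100000 nM. Putting 1-methyl-1H-tetrazol-5-yl on the sulfur in place of the larger heteroaryl group of compound 1 gives an at least 4.3-fold higher number from compound 1 to compound 4 (0.63 log units; beyond the scatter), so the weakening beyond the scatter now appears with two different single five-membered aromatic rings on this sulfur, not one. The step between compound 3 and compound 4 cannot be read, and the two rings cannot be placed in any order: the limit of > 100000 nM in this assay, at which 2 of the 4 values shown sit.

From the compounds shown here alone, how far beyond the limit compound 3 and compound 4 lie remains open, as does whether any single ring on this sulfur, with the amide part kept as in compound 1, can reach the level of compound 1. A six-membered ring such as pyridin-2-yl, or a five-membered ring bearing an amine or a carboxylic acid, would show whether the weak readings belong to single rings in general or only to 1,3,4-thiadiazol-2-yl and 1-methyl-1H-tetrazol-5-yl.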